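Halogen swap on the aryl ring of a shared core

A few compounds are considered here, and "the series" means these few. Any claim that something is new, unique, unknown or untested is made for them only; others in the source may bear on it.

compound 1, `N#CC1=C(N)OC(c2c[nH]c3ccccc23)=C(C#N)C1c1ccccc1F`: 22800 nM
compound 2, `N#CC1=C(N)OC(c2c[nH]c3ccccc23)=C(C#N)C1c1ccc(Br)cc1`: 21800 nM

Of the two compounds measured in a functional assay on MCF7 cells (Homo sapiens) for cytotoxicity, read by MTT assay, with a stated time of 24 h (a lower number here means a stronger inhibitor of growth, a higher number a weaker inhibitor of growth), compound 2 gives 21800 nM, the lowest of the two numbers, while compound 1 gives 22800 nM, a gap within the scatter. Among the measured compounds shown here, the only step bearing on the next change is a 1.0-fold lower number from compound 1 to compound 2 (0.02 log units; within the scatter), where an aryl group with a different halogen at a different place was exchanged without moving the number beyond the scatter. Compound 3, `N#CC1=C(N)OC(c2c[nH]c3ccccc23)=C(C#N)C1c1ccc(F)cc1`, differs from compound 2 by fluoro in place of bromo on an aromatic carbon. For the measured compounds named here, since the one step that exchanges a halogen-bearing aryl group left the number essentially unchanged, no step beyond the scatter is expected here, in either direction, and the step is estimated as a 1.0-fold higher number from compound 2 to compound 3 (0.00 log units; within the scatter). Compound 3 is therefore expected to give about 22000 nM, with a range from 11000 nM to 45000 nM.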

Compound 3, concentration for 50% growth inhibition: 28000 nM
Beside the measured number, compound 3's estimate is 1.3-fold (0.10 log units) below it, within the range that was stated.
By their numbers in this assay, from the lowest: compounds 2, 1 and 3 (each within the scatter of the next).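

The earlier step changed the halogen and its place together, and this result separates the two in this assay. With the place held, fluoro for bromo on an aromatic carbon, para to a large group, gives a 1.3-fold higher number from compound 2 to compound 3 (0.11 log units; within the scatter), and with the halogen held, 4-fluorophenyl for 2-fluorophenyl gives a 1.2-fold higher number from compound 1 to compound 3 (0.09 log units; within the scatter), so neither change alone moves the number beyond the scatter among these compounds. No measurement is available that would explain these small steps.

Going by these compounds, all three compounds carry a single halogen on this aryl ring, so it remains open whether an amine, a hydroxyl or a carboxylic acid in that place would shift the number beyond the scatter. Also open, on these data alone, is how the number responds to a change elsewhere on the shared core, such as an amide in place of a nitrile.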